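Back from a benzyl amide to an anilide

A few compounds are considered here, and "the series" means these few. Any claim that something is new, unique, unknown or untested is made for them only; others in the source may bear on it.

Compound 1 `COc1cccc(NC(=O)/C=C/c2coc3cc(OC)ccc3c2=O)c1` gives 12800 nM in a functional assay on A549 cells (Homo sapiens) for inhibition, read by MTT assay, with a stated time of 48 h; a lower number here means a stronger inhibitor, a higher number a weaker inhibitor. Compound 2 `COc1ccc2c(=O)c(/C=C/C(=O)NCc3cccc(F)c3)coc2c1` gives 26900 nM in this assay, the higher of the two numbers. Going by the values given here, the only measured step, a 2.1-fold higher number from compound 1 to compound 2 (0.32 log units; beyond the scatter), swapped 3-methoxyphenyl for 3-fluorobenzyl on the amide nitrogen and raised the number. Compound 3 `COc1ccc2c(=O)c(/C=C/C(=O)Nc3ccccc3OC)coc2c1` is not yet measured; it differs from compound 2 in one place: 2-methoxyphenyl in place of 3-fluorobenzyl on an amide-type nitrogen. Returning to a methoxyphenyl is expected to roughly undo that earlier step, giving a 1.9-fold lower number from compound 2 to compound 3 (0.28 log units; within the scatter). Compound 3 is therefore expected to give about 14000 nM in this assay, within a range from 6000 nM to 32000 nM.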

Compound 3, half-maximal inhibitory concentration: > 100000 nM
Compound 3: only a limit was reported; the forecaster's own chance of this, stated with the estimate: 5%; middle value at least 7.1-fold (0.85 log units) away from the limit.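

In this assay compound 3 gives only a limit of the assay, not a number: the limit of > 100000 nM in this assay, at which 1 of the 3 values shown sits. Changing 3-methoxyphenyl to 2-methoxyphenyl on the amide-type nitrogen gives an at least 7.8-fold higher number from compound 1 to compound 3 (0.89 log units; beyond the scatter), so these two methoxyphenyl groups are not interchangeable here, and an anilide alone does not secure a measurable number. Putting 2-methoxyphenyl in place of 3-fluorobenzyl gives an at least 3.7-fold higher number from compound 2 to compound 3 (0.57 log units; beyond the scatter).

On these data alone, the true size of both steps remains unknown. Also open, as far as these compounds go, is whether an amine or a carboxylic acid in place of the methoxy group would bring back a measurable number.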